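The source may report more compounds than this note shows. Statements on the series, on what has been measured and on what is new or still open speak of the compounds shown alone.

Measured compounds in an assay on HEK293 cells for inhibition of Lysophosphatidylserine lipase ABHD12 (Homo sapiens), read by scintillation counting, with stated times of 30 min and 5 min; on this read-out lower numbers stand for stronger inhibition and higher numbers for weaker inhibition:
- compound 1 `Cc1ccc(C(=O)NC2CCCCCC2)c(=O)n1Cc1ccc(F)cc1` gives > 10000 nM, which is a limit of the assay.
- compound 2 `COc1ccc(-c2cc(C(=O)NC3CCCCCC3)c(OCc3ccc(F)cc3)nc2C)cc1` gives > 10000 nM, also a limit.
- compound 3 `Cc1c(Cl)cc(C(=O)NC2CCCCCC2)c(=O)n1Cc1ccc(F)cc1` gives > 10000 nM, again a limit.

Compound 3 therefore stands only at a limit in this assay, and the two other values shown are limits as well (the limit of > 10000 nM in this assay, at which 3 of the 3 values shown sit). Among the measured compounds shown here, the one step between measured compounds that differ in one place, from compound 1 to compound 3, is a step that the two limits leave unreadable from compound 1 to compound 3, so its size cannot be read.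

Compound 4 `Cc1c(-c2ccccc2)cc(C(=O)NC2CCCCCC2)c(=O)n1Cc1ccc(F)cc1` differs from compound 3 by phenyl in place of chloro on an aromatic carbon, ortho to a methyl group, two atoms from the ring nitrogen, meta to a 4-fluorobenzyl group, meta to a large group, para to a group of 1 heavy atom. No measured step bears on this change beyond the unreadable one from compound 1 to compound 3, and with every shown value at a limit there is no readable direction to carry over. The expectation for compound 4 is accordingly a step of a number no higher from compound 3 to compound 4 (the limit leaves the size open), with a wide range and a substantial chance of another limit. Compound 4 is estimated at 10000 nM, expected between 2000 nM and 30000 nM.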

Compound 4, half-maximal inhibitory concentration: > 10000 nM
Compound 4: no number, only a limit; the forecaster's own chance of this, stated with the estimate: 65%; the middle value sits exactly at the limit.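

No new step can be read: compound 4 stands at a limit, as do compound 1 and compound 3, so its steps from both stay unreadable. The compounds shown leave open whether any change to the shared core yields a readable value, with every result so far at the same limit: the limit of > 10000 nM in this assay, at which 4 of the 4 values shown sit.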